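Phenyl for Heptyl on a Chlorinated Sulfonamide Ring

The source may hold more compounds than are shown below. What is called first, only, known or untested is meant among the compounds shown, and "the series" means these compounds.

Of the compounds shown here, three of one series have been measured in a functional assay on SW1573 cells (Homo sapiens) for antiproliferative activity, read by sulforhodamine B assay, with a stated time of 48 h; a lower number here means a stronger inhibitor of growth, a higher number a weaker inhibitor of growth. Compound 1 `Cc1ccc(S(=O)(=O)N2CC[C@@H](Cl)C[C@@H]2CC(C)C)cc1` gives 19000 nM, compound 2 `Cc1ccc(S(=O)(=O)N2CCC(Cl)=CC2CC(C)C)cc1` gives 31000 nM, and compound 3 `CCCCCCCC1C=C(Cl)CCN1S(=O)(=O)c1ccc(C)cc1` gives 49000 nM. Compound 3 thus shows the highest of the three numbers; compound 2 is the nearest to it, and the two lie within the usual scatter of each other, while compound 1 is the furthest from it, and that gap lies beyond the scatter.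

Compound 4 `Cc1ccc(S(=O)(=O)N2CCC(Cl)=CC2c2ccccc2)cc1` differs from compound 3 in one place: phenyl in place of heptyl on a saturated ring carbon. Among the measured compounds shown here, only one measured step touches that part of the molecule. The step of a 1.6-fold higher number from compound 2 to compound 3 (0.20 log units; within the scatter) altered the same chain and moved the number only within the scatter. For the measured compounds named here, no measured pair exchanges a chain for an aromatic ring, so the direction of this particular change cannot be read from the data. The step is therefore expected to be small, a 1.4-fold lower number from compound 3 to compound 4 (0.15 log units; within the scatter). Compound 4 is estimated at 35000 nM, with a range from 10000 nM to 100000 nM that reflects the missing precedent.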

Compound 4, concentration for 50% growth inhibition: 16000 nM
Compound 4: middle estimate off by 2.2-fold (0.34 log units), on the high side; the measured number falls inside the stated range.
By their numbers in this assay, from the lowest: compounds 4, 1, 2 and 3 (each within the scatter of the next, the first and the last beyond it).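

Among the compounds shown here, exchanging heptyl for phenyl on the saturated ring carbon next to the ring nitrogen produces, in this assay, the first step at this position that lies beyond the scatter (a 3.1-fold lower number from compound 3 to compound 4 (0.49 log units; beyond the scatter)), whereas the only earlier step touching this group stayed within it (a 1.6-fold higher number from compound 2 to compound 3 (0.20 log units; within the scatter)). The same position therefore does respond to the group it carries, although only modestly, and this is visible against heptyl but not against isobutyl, where the exchange for phenyl remains within the scatter (a 1.9-fold lower number from compound 2 to compound 4 (0.29 log units; within the scatter)), so phenyl and isobutyl cannot be told apart here. Nothing available accounts for the difference between phenyl and heptyl at this position.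

The compounds shown leave open whether the lower number with phenyl belongs to an aromatic ring as such, since a saturated ring such as cyclohexyl, or a shorter chain such as propyl, would be needed in the same place to separate that from the loss of the heptyl chain. They also leave open whether a substituted ring such as 4-methoxyphenyl or a pyridine would move the number further, and whether phenyl would act the same way on the saturated chlorinated ring of compound 1.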